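Fluoro for Hydrogen on the 2-Chlorophenyl of Compound 2

The compounds below may be only part of what the source reports. "The series", "measured", "known", "first", "only" and "open" are said of these compounds alone.

The series shares one core, seen in compound 2 `O=C(Nc1ccc(Cl)c(-c2nnc3c(Cl)cccn23)c1)c1ccccc1Cl`. Among the compounds with values here, in a functional assay on MCF7 cells (Homo sapiens) for antiproliferative activity, read by MTT assay, with a stated time of 72 h (on this read-out lower numbers stand for stronger inhibition and higher numbers for weaker inhibition), compound 2 gives 92200 nM, the only number among the three measured compounds. Compound 1 and compound 3 each return only a limit. Compound 1 `CS(=O)(=O)c1ccc(C(=O)Nc2ccc(Cl)c(-c3nnc4c(Cl)cccn34)c2)c(Cl)c1` reaches only the limit > 100000 nM in this assay. Compound 3 `O=C(Nc1ccc(Cl)c(-c2nnc3c(Cl)cccn23)c1)c1ccon1` likewise returns the limit > 100000 nM in this assay. Both measured steps are set against that limit of > 100000 nM in this assay, at which 2 of the 3 values shown sit: an at least 1.0-fold lower number from compound 1 to compound 2 (0.03 log units; that floor lies within the scatter) for hydrogen in place of methylsulfonyl on an aromatic carbon, and an at least 1.0-fold higher number from compound 2 to compound 3 (0.03 log units; that floor lies within the scatter) for 1,2-oxazol-3-yl in place of 2-chlorophenyl on a carbonyl carbon. Both floors lie within the scatter, so neither step records a real change.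

Compound 4 `O=C(Nc1ccc(Cl)c(-c2nnc3c(Cl)cccn23)c1)c1ccc(F)cc1Cl` differs from compound 2 by fluoro in place of hydrogen on an aromatic carbon. Within the data shown here, neither measured step touches a fluoro group, so no step bears on this change directly; the only guide is that compound 2 gives 92200 nM. Compound 1 and compound 3 return only limits. The step expected, a 1.0-fold lower number from compound 2 to compound 4 (0.01 log units; within the scatter), is none beyond the scatter, in no direction. Compound 4 is estimated at 90000 nM in this assay, within 40000 nM to 200000 nM, with a fair chance that only a limit is returned.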

Compound 4, half-maximal inhibitory concentration: > 100000 nM
Compound 4: a limit, no number; the forecaster's own chance of this, stated with the estimate: 45%; at least 1.1-fold (0.04 log units) between middle value and limit.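

In this assay, the change from 2-chlorophenyl to 2-chloro-4-fluorophenyl gives an at least 1.0-fold higher number from compound 2 to compound 4 (0.03 log units; that floor lies within the scatter), so fluoro in place of hydrogen on this carbon, meta to a chloro group and para to a large group, records no real change. Compound 4 returns a limit and not a number, and the steps to it from compound 1 and from compound 3 cannot be read, as each joins two limits. Compound 2 remains the only one of the four compounds with a number, and the new result adds one more value at the limit: the limit of > 100000 nM in this assay, at which 3 of the 4 values shown sit.

The compounds shown leave open whether another group on this carbon, such as an amine, a methoxy group or a carboxylic acid, would give a number clearly lower than that of compound 2. Also open, as far as these compounds go, is how a saturated ring such as cyclohexyl would read on the carbonyl carbon in place of 2-chlorophenyl.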